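This account rests on a few compounds, and the source may have more. Where it says the series, first, only, none or still open, it means among the compounds named here.

Measured so far in a functional assay on PC-3 cells (Homo sapiens) for cytotoxicity, read by MTT assay, with a stated time of 72 h; on this read-out lower numbers stand for stronger inhibition and higher numbers for weaker inhibition:
compound 1 `O=S(=O)(c1ccccc1)c1nc2ccccc2nc1N1CCCC(O)C1` gives 2100 nM
compound 2 `COc1ccc(S(=O)(=O)c2nc3ccccc3nc2N2CCCC(O)C2)cc1` gives 3410 nM

Among the measured compounds shown here, compound 2 stands as the higher of the two numbers in this assay; its nearest neighbour is compound 1, and the only measured step, a 1.6-fold higher number from compound 1 to compound 2 (0.21 log units; within the scatter), lies within the scatter. Compound 3 `O=S(=O)(c1ccc(Br)cc1)c1nc2ccccc2nc1N1CCCC(O)C1` differs from compound 2 by bromo in place of methoxy on an aromatic carbon. For the measured compounds named here, no measured step introduces bromo; the one step known touches the same aromatic carbon but with a different group and was small, so it bears on this change only loosely. A step of no more than the scatter is therefore expected, a 1.3-fold lower number from compound 2 to compound 3 (0.12 log units; within the scatter). Compound 3 is estimated at 2600 nM, within a range of 1000 nM to 6500 nM.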

Compound 3, half-maximal inhibitory concentration: 3690 nM
Compound 3: the middle estimate sits 1.4-fold (0.15 log units) below what was measured, within the range that was stated.
By their numbers in this assay, from the lowest: compounds 1, 2 and 3 (each within the scatter of the next).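

In this assay bromo replacing methoxy on the aromatic carbon para to a large group gives a 1.1-fold higher number from compound 2 to compound 3 (0.03 log units; within the scatter) and bromo replacing hydrogen there gives a 1.8-fold higher number from compound 1 to compound 3 (0.24 log units; within the scatter) as its step. Hydrogen, methoxy and bromo at this carbon therefore cannot be told apart, and a halogen now joins methoxy as a replacement with no readable change. No supporting evidence bears on this result.

As far as these compounds go, whether an amine or a carboxylic acid at this carbon would move the number beyond the scatter remains open. Changes elsewhere on the shared core also remain open.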